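Aryl variation on an alkyne series of metabotropic glutamate receptor 5 modulators

The source may report more compounds than this note shows. Statements on the series, on what has been measured and on what is new or still open speak of the compounds shown alone.

The measured compounds and their values:
compound 1, `C[C@@H](NC(=O)c1ccc(C#Cc2ccccc2)cn1)C(C)(C)O`, 60.9%
compound 2, `C[C@@H](NC(=O)c1ccc(C#Cc2ccc(F)cc2F)cn1)C(C)(C)O`, 61.2%
compound 3, `Cc1ccc(C#Cc2ccc(C(=O)N[C@H](C)C(C)(C)O)nc2)cc1`, 63.1%

These three compounds share one core and differ only in the group on the triple-bonded carbon. In a functional assay on HEK293 cells for positive allosteric modulation of metabotropic glutamate receptor 5 (Rattus norvegicus), read by fluorescence and calcium flux (on this read-out higher numbers stand for larger maximal responses and lower numbers for smaller maximal responses), compound 2 stands second of the three numbers; its nearest neighbour is compound 1 with a number 0.3 percentage points higher from compound 1 to compound 2 (within the scatter), and the furthest is compound 3 with a number 1.9 percentage points higher from compound 2 to compound 3 (within the scatter). Compound 1 and compound 3 are separated by a number 2.2 percentage points higher from compound 1 to compound 3 (within the scatter). All three steps are within the scatter, so the three measured compounds cannot be told apart on this read-out.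

The unmeasured compound 4, `C[C@@H](NC(=O)c1ccc(C#Cc2ncccc2F)cn1)C(C)(C)O`, differs from compound 2 as follows: 3-fluoropyridin-2-yl in place of 2,4-difluorophenyl on a triple-bonded carbon. Among the compounds with values here, no measured step introduces a ring with a hetero atom in this position, so no step bears directly on the change. The steps that do touch this position, from compound 1 to compound 2 and from compound 2 to compound 3, were both within the scatter, which gives no ground to expect a change beyond the scatter in this assay from compound 2 to compound 4 either.

Compound 4 is therefore estimated at 61%, with a range from 47% to 74%, which is the expected step of a number 0.2 percentage points lower from compound 2 to compound 4 (within the scatter).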

Compound 4, largest response reached (reported as efficacy), in percent of the reference or control that the assay uses: 60.6%
Beside the measured number, compound 4's estimate is 0.4 percentage points above it, within the range that was stated.
By their numbers in this assay, from the lowest: compounds 4, 1, 2 and 3 (each within the scatter of the next).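

The 3-fluoropyridin-2-yl group brings the first ring with a hetero atom to the triple-bonded carbon, along with a hydrogen-bond acceptor that the rings on compounds 1, 2 and 3 lack, and in this assay the change gives (a number 0.6 percentage points lower from compound 2 to compound 4 (within the scatter)), (a number 0.3 percentage points lower from compound 1 to compound 4 (within the scatter)) and (a number 2.5 percentage points lower from compound 3 to compound 4 (within the scatter)). The range of groups at this position that leave the maximal response within the scatter therefore extends from carbon-only aromatic rings, with or without methyl or fluorine, to a fluorinated six-membered aromatic ring with one hetero atom, and the four compounds cannot be told apart on this read-out. Nothing in the information at hand accounts for this flat result or connects it to any measured property of the groups.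

The compounds shown leave open whether a group of another kind on the triple-bonded carbon, such as an aminomethyl group, a carboxylic acid or a longer alkyl chain, would move the number beyond the scatter. They also leave open whether a pyridine ring without the fluorine would behave as compound 4 does.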